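The compounds below may be only part of what the source reports. "The series", "measured", "known", "first", "only" and "open" are said of these compounds alone.

Measured in a physicochemical assay for solubility, read by nephelometry; a higher number here means a more soluble compound, a lower number a less soluble compound:
- Compound 1 `CC1(C)C(=O)N(c2ccc(SC(F)(F)F)cc2)C(=O)N1Cc1ccnc(N2CCCCC2)c1`: < 0.024 ug/mL, a limit
- Compound 2 `CC1(C)C(=O)N(c2ccc(SC(F)(F)F)cc2)C(=O)N1Cc1ccnc(F)c1`: 0.032 ug/mL

Within the data shown here, compound 2, at 0.032 ug/mL, holds the only actual number in this assay. The entry for compound 1 is a limit. Compound 3 `CC1(C)C(=O)N(c2ccc(SC(F)(F)F)cc2)C(=O)N1Cc1ccnc(NC2CCCCC2)c1` has not yet been measured. It carries cyclohexylamino in place of fluoro on an aromatic carbon, next to the ring nitrogen (cyclohexylamino in place of fluoro on an aromatic carbon).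

Among the measured compounds shown here, only one measured step bears on this change, and it runs the opposite way, putting fluoro in place of piperidin-1-yl at that carbon. That step is an at least 1.3-fold higher number from compound 1 to compound 2 (0.12 log units; that floor lies within the scatter). From the compounds shown here alone, its true size remains open, and its floor does not clear the usual scatter. Read in reverse, it suggests that replacing fluoro with cyclohexylamino should lead to a somewhat lower number, though only weakly. The expected step is a 1.6-fold lower number from compound 2 to compound 3 (0.20 log units; within the scatter), a small move that may not stand clear of the scatter. The estimate for compound 3 is 0.02 ug/mL, with an expected range from 0.01 ug/mL to 0.045 ug/mL. The assay may well return only a limit for it.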

Compound 3, solubility: < 0.025 ug/mL
Compound 3 gave a limit, no number; the forecaster's own chance of this, stated with the estimate: 55%; the middle value is on the limit's open side.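

In this assay, from the compounds shown here alone, putting cyclohexylamino in place of fluoro on this aromatic carbon, next to the ring nitrogen, gives an at least 1.2-fold lower number from compound 2 to compound 3 (0.10 log units; that floor lies within the scatter), so the true size of the change remains open. Compound 3 gives a limit and not a number: < 0.025 ug/mL. With cyclohexylamino as with piperidin-1-yl at this carbon, this assay returns only a limit, so the step from compound 1 to compound 3 cannot be read, and compound 2 remains the only one of the three with an actual number.

The compounds shown leave open whether any group at this carbon can give a number in this assay that stands clear of the scatter around compound 2, at 0.032 ug/mL. A morpholine ring, a small open-chain amine such as dimethylamino or a carboxylic acid at this carbon would test that, and each would give a step that could be read only if it returned an actual number rather than a limit.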